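Chain methyl removal on the isopropyl urea

The source may report more compounds than this note shows. Statements on the series, on what has been measured and on what is new or still open speak of the compounds shown alone.

Measured compounds in a functional assay on cells (Neutrophil, Homo sapiens) for inhibition, with a stated time of 10 min; a lower number here means a stronger inhibitor, a higher number a weaker inhibitor:
compound 1 `CCOC(=O)c1cnn(CC(C)O)c1NC(=O)Nc1ccc(F)cc1`: compound 1 gives > 10 nM, a limit of the assay.
compound 2 `CCOC(=O)c1cnn(CC(O)CC)c1NC(=O)Nc1ccc(F)cc1`: compound 2 gives 3.2 nM.
compound 3 `CCOC(=O)c1cnn(CC(O)CC)c1NC(=O)NC(C)C`: compound 3 gives > 10 nM, a limit of the assay.

Compound 3 therefore stands at the limit rather than at a number; this is the limit of > 10 nM in this assay, at which 2 of the 3 values shown sit.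

Compound 4 `CCOC(=O)c1cnn(CC(C)O)c1NC(=O)NC(C)C` differs from compound 3 by hydrogen in place of methyl on a saturated chain carbon, two bonds along the chain from an oxygen on a saturated carbon. The measured step that bears most directly on this change is the reverse one, an at least 3.1-fold lower number from compound 1 to compound 2 (0.49 log units; beyond the scatter), in which the methyl entered at the same place and the number came down. The other step, an at least 3.1-fold higher number from compound 2 to compound 3 (0.49 log units; beyond the scatter), concerns the urea end and is what put compound 3 at the limit; it does not touch the chain position itself.

Taking the methyl out again is expected to move the number in the direction opposite to the step from compound 1 to compound 2, that is upward, so compound 4 is expected to remain at the limit, with an estimated step that the limit leaves unreadable from compound 3 to compound 4. The estimate for compound 4 in this assay is 60 nM, with a range from 15 nM to 400 nM.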

Compound 4, half-maximal inhibitory concentration: 90 nM
The estimate for compound 4 lay 1.5-fold (0.18 log units) below the measured number, within the range that was stated.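

In this assay compound 4 gives 90 nM, but neither its step from compound 3 nor its step from compound 1 can be read. Compound 1 and compound 3 each stand at a limit, not a number: the limit of > 10 nM in this assay, at which 2 of the 4 values shown sit.

The compounds shown leave open the size of the chain methyl change on the isopropyl urea.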